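The source may report more compounds than this note shows. Statements on the series, on what has been measured and on what is new or still open speak of the compounds shown alone.

Measured compounds:
- compound 1 `Cc1c(Nc2ccc(C#N)cc2Cl)ncnc1OC1C2COCC1CN(S(=O)(=O)C1CC1)C2`: 844 nM
- compound 2 `Cc1c(Nc2ccc(C#N)cc2Cl)ncnc1OC1C2COCC1CN(C(=O)OC1(C)CC1)C2`: 33 nM

For the measured compounds named here, in a functional assay on HEK293 cells for agonist activity at Glucose-dependent insulinotropic receptor (Mus musculus), read by fluorescence and cAMP accumulation, with a stated time of 30 min (a lower number here means that less compound is needed, a higher number that more compound is needed for the effect), compound 2 holds the lowest of the two numbers; the only other point, compound 1, gives 844 nM, and the single step between them, a 26-fold lower number from compound 1 to compound 2 (1.41 log units; beyond the scatter), is large and concerns the substituent on the amine nitrogen in a ring. Compound 3 `COc1c(Nc2ccc(C#N)cc2Cl)ncnc1OC1C2COCC1CN(C(=O)OC1(C)CC1)C2` differs from compound 2 by methoxy in place of methyl on an aromatic carbon. Going by the values given here, this position is not touched by any measured step, so the large step seen on the ring nitrogen does not bear on it and there is no measured precedent for exchanging methyl for methoxy on the core. The expectation therefore rests on compound 2 alone: the step expected, a 1.1-fold higher number from compound 2 to compound 3 (0.03 log units; within the scatter), is none beyond the scatter, with the wider range reflecting the absence of any precedent. Compound 3 is estimated at 35 nM in this assay, between 10 nM and 120 nM.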

Compound 3, half-maximal effective concentration in the Glucose-dependent insulinotropic receptor assay: 43 nM
Compound 3: the middle estimate sits 1.2-fold (0.09 log units) below what was measured, within the range that was stated.
By their numbers in the Glucose-dependent insulinotropic receptor assay, from the lowest: compounds 2 and 3 (each within the scatter of the next); then compound 1.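

For the compounds shown here, in the Glucose-dependent insulinotropic receptor assay, the first measured change on this aromatic carbon, ortho to a (2-chloro-4-cyanophenyl)amino group, gives no separation between methyl and methoxy (a 1.3-fold higher number from compound 2 to compound 3 (0.11 log units; within the scatter)). The same exchange does separate the pair in a physicochemical assay for solubility, at pH 7.4 (a lower number here means a less soluble compound, a higher number a more soluble compound), where compound 2 gives 6000 nM and compound 3 gives 30000 nM, and methoxy in place of methyl goes with the more soluble compound: the measured solubility of compound 2, 6000 nM, and of compound 3, 30000 nM, a 5.0-fold higher number (0.70 log units; beyond the scatter). This position therefore accepts methoxy without a step beyond the scatter in the Glucose-dependent insulinotropic receptor assay, while the solubility read-out moves beyond it, though this rests on one pair only.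

Still open, on these data alone, is whether an ethoxy group or an amine on this aromatic carbon would hold the number in the Glucose-dependent insulinotropic receptor assay. Also open, as far as these compounds go, is whether methoxy would give a similar step in the physicochemical assay with cyclopropylsulfonyl in place of the carbamate on the amine nitrogen in a ring.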